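Swapping a Hexyl Tail for a Phenyl Ring

The source may report more compounds than this note shows. Statements on the series, on what has been measured and on what is new or still open speak of the compounds shown alone.

In a functional assay on L1210 cells (Mus musculus) for antiproliferative activity, read by MTT assay, with a stated time of 2 days (a lower number here means a stronger inhibitor, a higher number a weaker inhibitor), compound 1 `CCCCCCCCC#Cc1cn(C/C=C/CN2C(=O)c3ccccc3C2=O)c(=O)[nH]c1=O` gives > 250000 nM, which is a limit and not a number. Its relative, compound 2 `CCCCC#Cc1cn(C/C=C\CN2C(=O)c3ccccc3C2=O)c(=O)[nH]c1=O`, gives 109000 nM. Compound 3 `O=C1c2ccccc2C(=O)N1C/C=C/Cn1cc(C#CCCc2ccccc2)c(=O)[nH]c1=O` alters compound 1 in one place: phenyl in place of hexyl on a saturated chain carbon, two bonds along the chain from a triple-bonded carbon, with phenyl in place of hexyl on a saturated chain carbon, two bonds along the chain from a triple-bonded carbon. Among the compounds with values here, no measured pair of compounds isolates this change, so any forecast is rough. A small move toward stronger inhibition is expected, an estimated at least 2.0-fold lower number from compound 1 to compound 3 (0.31 log units; beyond the scatter). Compound 3 is expected near 120000 nM, with an estimated range of 40000 nM to 300000 nM.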

Compound 3, half-maximal inhibitory concentration: 44000 nM
For compound 3 the middle estimate is 2.7-fold (0.44 log units) above the measured one, within the range that was stated.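

Phenyl in place of hexyl on a saturated chain carbon, two bonds along the chain from a triple-bonded carbon, gives an at least 5.6-fold lower number from compound 1 to compound 3 (0.75 log units; beyond the scatter) in this assay. Within the data shown here, this is the first readable step at this position, and it shows that a ring there can be compatible with measurable activity in these cells. Compound 1 gives only a limit, so this step has a minimum size but no exact one: the limit of > 250000 nM in this assay, at which 1 of the 3 values shown sits.

The compounds shown leave open whether a cyclohexyl group would do the same as phenyl. They also leave open how a pyridyl ring or a terminal amine at this place would compare.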